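The compounds below may be only part of what the source reports. "The series", "measured", "known", "first", "only" and "open" are said of these compounds alone.

Compound 1 `Cc1ccc2c(=O)[nH]c(-c3ccccc3C)nc2c1` shows no measurable effect in a functional assay on T47D cells (Homo sapiens) for cytotoxicity, read by MTT assay, with a stated time of 2 days; on this read-out lower numbers stand for stronger inhibition and higher numbers for weaker inhibition. Compound 1 gives > 50000 nM, which is a limit of the assay and not a number. The close relative compound 2 `Cc1ccc2nc(-c3ccccc3C)[nH]c(=O)c2c1` gives > 50000 nM in this assay, again only a limit. The data so far therefore amount to the limit of > 50000 nM in this assay, at which 2 of the 2 values shown sit. Compound 3 `Cc1ccc2c(=O)[nH]c(-c3ccccc3F)nc2c1` departs from compound 1 at one place, with fluoro in place of methyl on an aromatic carbon, ortho to a large group: fluoro in place of methyl on an aromatic carbon. Since compound 1 offers only the limit > 50000 nM, any forecast has no firm number to start from, and no shift beyond the scatter is expected in this assay, in either direction. The expected change is a number no higher from compound 1 to compound 3 (the limit leaves the size open). For compound 3 the estimated value is 50000 nM, with an expected range from 20000 nM to 100000 nM.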

Compound 3, half-maximal inhibitory concentration: > 50000 nM
Compound 3: no number, only a limit; the forecaster's own chance of this, stated with the estimate: 75%; the middle value sits exactly at the limit.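

No step can be read between compound 1 and compound 3 in this assay: both give only a limit, not a number. The compounds shown leave open what number each would give in this assay, and whether fluoro in place of methyl changes anything there.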